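A few compounds are considered here, and "the series" means these few. Any claim that something is new, unique, unknown or untested is made for them only; others in the source may bear on it.

Measured compounds:
compound 1 `O=C(Nc1ccc(-n2ncc3c(C(F)(F)F)cccc32)cc1)Nc1ccc(Cl)c(C(F)(F)F)c1` — 3000 nM
compound 2 `CNc1cccc2c1cnn2-c1ccc(NC(=O)Nc2ccc(Cl)c(C(F)(F)F)c2)cc1` — 4900 nM
compound 3 `O=C(Nc1ccc(-n2ncc3c(C(F)(F)F)cccc32)cc1)Nc1ccc(C(F)(F)F)cc1` — 800 nM

All three were run in a functional assay on A549 cells (Homo sapiens) for cytotoxicity, read by MTT assay, with a stated time of 72 h; a lower number here means a stronger inhibitor, a higher number a weaker inhibitor. Among them compound 3 gives the lowest number, 800 nM; the step of a 3.8-fold lower number from compound 1 to compound 3 (0.57 log units; beyond the scatter) lies beyond the scatter, and the value of compound 2, 4900 nM, stands further still from that of compound 3. The other measured step, a 1.6-fold higher number from compound 1 to compound 2 (0.21 log units; within the scatter), falls within the scatter.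

Compound 4 `O=C(Nc1ccc(-n2ncc3c(Cl)cccc32)cc1)Nc1ccc(C(F)(F)F)cc1` is not yet measured. It differs from compound 3 by one change: chloro in place of trifluoromethyl on an aromatic carbon.

Of the two measured steps, only a 1.6-fold higher number from compound 1 to compound 2 (0.21 log units; within the scatter) touches the same aromatic carbon of the fused ring system, and there the exchange of trifluoromethyl for methylamino left the number within the scatter. The step of a 3.8-fold lower number from compound 1 to compound 3 (0.57 log units; beyond the scatter) concerns the other aryl ring and does not bear on this change. Given that, compound 4 is expected to show no step beyond the scatter, a 1.1-fold higher number from compound 3 to compound 4 (0.05 log units; within the scatter). The estimate for compound 4 in this assay is therefore 900 nM, with a range from 400 nM to 2500 nM.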

Compound 4, half-maximal inhibitory concentration: 6000 nM
Beside the measured number, compound 4's estimate is 6.7-fold (0.82 log units) below it; the measured number lies above the stated range.
By their numbers in this assay, from the lowest: compound 3; then compounds 1, 2 and 4 (each within the scatter of the next).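

In this assay the exchange of trifluoromethyl, with its 4 heavy atoms, for chloro, with 1 heavy atom, gave a 7.5-fold higher number from compound 3 to compound 4 (0.88 log units; beyond the scatter) and so showed that this aromatic carbon of the fused system is not indifferent to the group it carries. Within the data shown here, the only earlier change at this carbon, a 1.6-fold higher number from compound 1 to compound 2 (0.21 log units; within the scatter) for methylamino in place of trifluoromethyl, stayed within the scatter, so that result does not extend to every replacement of trifluoromethyl here, although that earlier step carried 4-chloro-3-(trifluoromethyl)phenyl where the new step carries 4-(trifluoromethyl)phenyl. Nothing available here accounts for the size of the new step.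

The compounds shown leave open whether the two steps differ through the entering group or through that other aryl group, since chloro and methylamino at this carbon are each seen with only one of the two aryl groups. They also leave open how this carbon would behave with a methyl, a methoxy, a bromo or a nitrile in place of trifluoromethyl, or with hydrogen alone.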